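This account rests on a few compounds, and the source may have more. Where it says the series, first, only, none or still open, it means among the compounds named here.

Two sulfonate esters open this set. In a functional assay on HT-1080 cells (Homo sapiens) for antiproliferative activity, read by sulforhodamine B assay, with a stated time of 48 h (on this read-out higher numbers stand for weaker inhibition and lower numbers for stronger inhibition), compound 1 `CC(=O)Nc1cccc(S(=O)(=O)Oc2ccccc2C(C)C)c1` gives 21000 nM, and in this assay compound 2 `CC(=O)Nc1ccc(S(=O)(=O)Oc2ccccc2I)cc1` gives 17000 nM; these two numbers sit within the scatter of each other, so compound 2 cannot be set apart from compound 1 on this evidence. Compound 3 `CCC(=O)Nc1ccc(S(=O)(=O)Oc2ccccc2I)cc1` differs from compound 2 by methyl in place of hydrogen on a saturated chain carbon bound to a carbonyl carbon. Within the data shown here, no measured pair shows what such a change does here, so the step is expected to stay within the scatter, with no direction favoured. Compound 3 is therefore expected to give about 17000 nM, in a range from 8000 nM to 36000 nM, a step of no change at the digits printed from compound 2 to compound 3 (within the scatter).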

Compound 3, half-maximal inhibitory concentration: 7200 nM
Beside the measured number, compound 3's estimate is 2.4-fold (0.37 log units) above it, outside the stated range (below it).
By their numbers in this assay, from the lowest: compound 3; then compounds 2 and 1 (each within the scatter of the next).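

Lengthening acetamido to propanoylamino gives the first difference in this set that lies beyond the scatter: in this assay there is a 2.4-fold lower number from compound 2 to compound 3 (0.37 log units; beyond the scatter) and so modestly stronger inhibition. The saturated chain carbon bound to a carbonyl carbon therefore accepts a methyl without loss, and one added carbon here changes the read-out. No measurement at hand explains this shift. From the compounds shown here alone, a single step sets no trend, so it remains open whether a longer chain such as butanoyl would go further or reverse the gain. Going by these compounds, an amine or a carboxylic acid at this place also remains untested by these compounds.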